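Swapping the Ring on the Alkyne: Compound 4 Predicted

A few compounds are considered here, and "the series" means these few. Any claim that something is new, unique, unknown or untested is made for them only; others in the source may bear on it.

Compound 1 `CNC(=O)[C@@]12C[C@@H]1[C@@H](n1cnc3c(NC)nc(C#Cc4ccccc4F)nc31)[C@H](O)[C@@H]2O` gives 20% in an assay on CHO cells for displacement of a labelled ligand from adenosine receptor A1 (Homo sapiens), read by scintillation counting, with a stated time of 60 min, tested at 10 uM; on this read-out lower numbers stand for less inhibition and higher numbers for more inhibition at the one concentration tested (going by the name of the read-out).
Compound 2 `CNC(=O)[C@@]12C[C@@H]1[C@@H](n1cnc3c(NC)nc(C#Cc4ccc(CO)cc4)nc31)[C@H](O)[C@@H]2O` gives 16% in this assay.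
Compound 3 `CNC(=O)[C@@]12C[C@@H]1[C@@H](n1cnc3c(NC)nc(C#Cc4ncccn4)nc31)[C@H](O)[C@@H]2O` gives 25% in this assay.

All three compounds share one core and differ only in the ring attached to the triple-bonded carbon. Compound 3 has the highest of the three numbers, but its lead is small: the step of a number 5 percentage points higher from compound 1 to compound 3 (within the scatter) and the step of a number 9 percentage points higher from compound 2 to compound 3 (within the scatter) both lie within the usual scatter, as does a number 4 percentage points lower from compound 1 to compound 2 (within the scatter), so the three compounds cannot be ordered with confidence.

Compound 4 `CNC(=O)[C@@]12C[C@@H]1[C@@H](n1cnc3c(NC)nc(C#Cc4cc(C)c(C)o4)nc31)[C@H](O)[C@@H]2O` has not yet been measured. It differs from compound 3 as follows: 4,5-dimethylfuran-2-yl in place of pyrimidin-2-yl on a triple-bonded carbon.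

Within the data shown here, none of the measured steps involves the entering ring, so the only guidance is that every ring exchange seen so far at this position moved the number by less than the scatter. On that basis a step of about a number 3 percentage points lower from compound 3 to compound 4 (within the scatter) is expected, meaning no change beyond the scatter in either direction.

Compound 4 is therefore estimated to give 22% in this assay, with a likely range from 8% to 38%.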

Compound 4, a percentage reported as inhibition, at one concentration (the size of the read-out at that concentration, not a potency): 15%
Compound 4: middle estimate off by 7 percentage points, on the high side; the range from low to high includes it.
By their numbers in this assay, from the lowest: compounds 4, 2, 1 and 3 (each within the scatter of the next).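

Compound 4 carries the only five-membered aromatic ring in the set, with one oxygen as its hetero atom, and 4,5-dimethylfuran-2-yl still stays within the scatter of each of the three six-membered rings in this assay: against pyrimidin-2-yl (a number 10 percentage points lower from compound 3 to compound 4 (within the scatter)), against 4-(hydroxymethyl)phenyl (a number 1 percentage points lower from compound 2 to compound 4 (within the scatter)) and against 2-fluorophenyl (a number 5 percentage points lower from compound 1 to compound 4 (within the scatter)). The place on the triple-bonded carbon therefore accepts a change of ring size, and an exchange of two ring nitrogens for one ring oxygen plus two methyl groups, without any of the four compounds separating from the others on this read-out. Nothing available here offers an explanation for this result.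

From the compounds shown here alone, all four compounds keep an aromatic ring at this place, so the effect of a saturated ring such as cyclohexyl, a plain alkyl chain in place of the ring, or an amine or a carboxylic acid on the ring remains open. With one read-out at one concentration, any real differences among these four rings, smaller than the scatter, also remain open.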